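The source may report more compounds than this note shows. Statements on the series, on what has been measured and on what is new or still open speak of the compounds shown alone.

Measured compounds and their values:

- Compound 1 `Cc1ccc(C)n1-c1ccsc1C(=O)O`: 70000 nM
- Compound 2 `Cn1cc(-c2n[nH]c3cc(N)ccc23)cn1`: 28800 nM
- Compound 3 `CC(C)Nc1ccc2c(-c3cnn(C)c3)n[nH]c2c1`: 46600 nM

All three compounds were tested in an assay on isolated protein for inhibition of tyrosine-protein kinase receptor UFO (Homo sapiens), with a stated time of 1.5 h; on this read-out higher numbers stand for weaker inhibition and lower numbers for stronger inhibition. Compound 3 gives 46600 nM, which is the second highest of the three numbers; compound 1 sits a 1.6-fold higher number from compound 2 to compound 3 (0.21 log units; within the scatter) apart from it only in the sense that its value is close, and compound 2 is the nearest neighbour on the other side, so all three values lie within the usual scatter of one another.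

The next compound, compound 4 `Cn1cc(-c2n[nH]c3cc(Nc4ccccc4)ccc23)cn1`, differs from compound 3 by one change: phenyl in place of isopropyl on a nitrogen on an aromatic ring. The same difference, cut one bond further out, reads: isopropylamino to anilino.

Among the measured compounds shown here, the one measured step that touches this same nitrogen is the change from hydrogen to isopropyl, which gave a 1.6-fold higher number from compound 2 to compound 3 (0.21 log units; within the scatter). That step did not move the number beyond the scatter, so the exchange of isopropyl for phenyl is expected to give at most a modest step in this assay, most likely none beyond the scatter, with direction uncertain. Compound 4 is therefore estimated at 40000 nM, with a range from 10000 nM to 150000 nM, which corresponds to an expected 1.2-fold lower number from compound 3 to compound 4 (0.07 log units; within the scatter).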

Compound 4, half-maximal inhibitory concentration: 219000 nM
Compound 4: middle estimate off by 5.5-fold (0.74 log units), on the low side, outside the stated range (above it).
By their numbers in this assay, from the lowest: compounds 2, 3 and 1 (each within the scatter of the next, the first and the last beyond it); then compound 4.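

In this assay the nitrogen on the aromatic ring turns out to be sensitive to what it carries: putting phenyl in place of isopropyl gives a 4.7-fold higher number from compound 3 to compound 4 (0.67 log units; beyond the scatter), and putting phenyl in place of hydrogen gives a 7.6-fold higher number from compound 2 to compound 4 (0.88 log units; beyond the scatter). The earlier step, a 1.6-fold higher number from compound 2 to compound 3 (0.21 log units; within the scatter), showed no change beyond the scatter, so this position accepts isopropyl about as well as hydrogen, while phenyl weakens inhibition. Nothing available explains why these two groups behave differently.

On these data alone, it stays open whether the ring itself or simply the larger number of carbons matters, which a cyclohexyl group or a longer chain on this nitrogen could help to separate. As far as these compounds go, it is also open whether a group such as an amine or a carboxylic acid on this nitrogen would strengthen inhibition.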